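Substituent swap on the aromatic ring: compound 2 to compound 3

A few compounds are considered here, and "the series" means these few. Any claim that something is new, unique, unknown or untested is made for them only; others in the source may bear on it.

Compound 1 `COC(=O)[C@@]1(C)CCC=C2[C@@H]1CC[C@@H](C)[C@]2(C)Cc1c(C)[nH]c2ccc(C)cc12` and compound 2 `COC(=O)[C@@]1(C)CCC=C2[C@@H]1CC[C@@H](C)[C@]2(C)Cc1c(C)[nH]c2ccc(Cl)cc12` share one core and differ at a single aromatic carbon. In a functional assay on HeLa cells (Homo sapiens) for inhibition, read by sulforhodamine B assay, with a stated time of 48 h (a higher number here means a weaker inhibitor of growth, a lower number a stronger inhibitor of growth), compound 1 gives 17000 nM, and compound 2 gives 12000 nM. Going by the values given here, the only measured step in the set is a 1.4-fold lower number from compound 1 to compound 2 (0.15 log units; within the scatter), so the two values sit within the scatter of one another; compound 2 holds the lowest of the two numbers, with compound 1 the nearest to it, and no ranking between them can be read from the data.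

Compound 3 `COC(=O)[C@@]1(C)CCC=C2[C@@H]1CC[C@@H](C)[C@]2(C)Cc1c(C)[nH]c2ccc(C(F)(F)F)cc12` carries the next change at the same aromatic carbon: trifluoromethyl in place of chloro on an aromatic carbon. Among the compounds with values here, no measured step involves trifluoromethyl at this site. Within the data shown here, the one step that bears on the position, a 1.4-fold lower number from compound 1 to compound 2 (0.15 log units; within the scatter), exchanged one small group for another there without moving the number beyond the scatter. The same outcome is expected here, a step of a 1.2-fold lower number from compound 2 to compound 3 (0.08 log units; within the scatter) in this assay, amounting to no change beyond the scatter. Compound 3 is therefore estimated at 10000 nM, with a range from 4000 nM to 25000 nM.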

Compound 3, concentration for 50% growth inhibition: 12000 nM
Estimate against measurement, compound 3: 1.2-fold (0.08 log units) below; the measured number falls inside the stated range.
By their numbers in this assay, from the lowest: compounds 2, 3 and 1 (each within the scatter of the next).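

In this assay, trifluoromethyl in place of chloro gives no change at the digits printed from compound 2 to compound 3 (within the scatter), and trifluoromethyl in place of methyl gives a 1.4-fold lower number from compound 1 to compound 3 (0.15 log units; within the scatter), so all three groups at this aromatic carbon now lie within the scatter of one another. The earlier pair compared only methyl with chloro; this result adds a change from one heavy atom in chloro to four in trifluoromethyl, and that difference in count does not separate compound 2 from compound 3. No measured information is available to explain why these numbers stay together at this position.

The compounds shown leave open whether a group of a different kind at this aromatic carbon, such as an amine, a carboxylic acid or a longer alkyl chain, would move the number beyond the scatter. They also leave open whether a change elsewhere on the shared core, such as a carboxylic acid in place of the methyl ester, would shift the number, and whether this position would stay as insensitive with that change in place.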